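The source may report more compounds than this note shows. Statements on the series, on what has been measured and on what is new or still open speak of the compounds shown alone.

In an ADME assay on KB cells (Homo sapiens) for cytotoxicity (a higher number here means that more compound is needed for the effect, a lower number that less compound is needed), compound 1 `CCOC(=O)N1[C@@H]2C=C[C@@](OC)(C(=O)c3c2cc(OC)c(OC)c3OCc2ccc(F)cc2)N1C(=O)OCC` gives 51.8 ug/mL. Compound 3 `COC(=O)N1[C@@H]2C=C[C@@](OC)(C(=O)c3c2cc(OC)c(OC)c3OCc2ccc(F)cc2)N1C(=O)OC` gives 56.6 ug/mL, and these two values lie within the scatter of each other. For compound 2 `COC(=O)N1[C@@H]2C=C[C@@](OC)(C(=O)c3c2cc(OC)c(OC)c3OCc2ccc(OC)cc2)N1C(=O)OC`, this assay reports only a limit, > 300 ug/mL. Compound 1 therefore sits with compound 3 among the two compounds that have a measured number.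

Compound 4 `CCOC(=O)N1[C@@H]2C=C[C@@](OC)(C(=O)c3c2cc(OC)c(OC)c3OCc2ccccc2F)N1C(=O)OCC` has not yet been measured. It departs from compound 1 by one change, 2-fluorophenyl in place of 4-fluorophenyl on a saturated chain carbon bound to an oxygen on an aromatic ring, or 4-fluorobenzyl to 2-fluorobenzyl when the cut is made one bond further out.

For the measured compounds named here, only one measured step bears on this group, and only indirectly. That step, an at least 5.3-fold lower number from compound 2 to compound 3 (0.72 log units; beyond the scatter), puts fluoro in place of methoxy on an aromatic carbon. It shows that a swap on this group can register in this assay, but it exchanges one substituent for another, whereas compound 4 keeps the fluorine and moves it. Going by the values given here, no measured pair tests such a move, so no step beyond the scatter is expected, though the uncertainty is wide. The expected step is a 1.2-fold higher number from compound 1 to compound 4 (0.06 log units; within the scatter). For compound 4 the estimated value is 60 ug/mL, with an expected range from 20 ug/mL to 200 ug/mL.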

Compound 4, concentration for half-maximal effect: 99.7 ug/mL
The estimate for compound 4 lay 1.7-fold (0.22 log units) below the measured number, and the stated range covers the measured number.
By their numbers in this assay, from the lowest: compounds 1, 3 and 4 (each within the scatter of the next). At a limit, above all of these: compound 2.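

For the compounds shown here, with 2-fluorophenyl in place of 4-fluorophenyl on a saturated chain carbon bound to an oxygen on an aromatic ring, this assay shows a 1.9-fold higher number from compound 1 to compound 4 (0.28 log units; within the scatter) and so gives the first reading of a move of the fluorine rather than an exchange of the substituent. The earlier step, an at least 5.3-fold lower number from compound 2 to compound 3 (0.72 log units; beyond the scatter) and beyond the scatter, had shown only that replacing methoxy with fluoro can register on this group, whereas this pair shows that moving the fluorine, with the atoms unchanged, produces no step beyond the scatter in this one comparison. The single line of supporting data concerns a limit reached by another compound and offers no explanation for this step.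

The compounds shown leave open how a plain benzyl group, with no substituent on its ring, would compare with 4-fluorobenzyl and 2-fluorobenzyl, and whether chloro or a nitrile would read like fluoro on that ring. They also leave open whether the same move of the fluorine would read alike with the methyl esters of compound 3 in place of the ethyl esters of compound 1.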